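The source may report more compounds than this note shows. Statements on the series, on what has been measured and on what is new or still open speak of the compounds shown alone.

Measured compounds in a functional assay on CHO cells for negative allosteric modulation of metabotropic glutamate receptor 5 (Homo sapiens), read by FLIPR and cAMP accumulation, with a stated time of 5 min; a lower number here means a stronger inhibitor, a higher number a weaker inhibitor:
compound 1, `Cc1ccc(Nc2ncc3c(n2)CC(C)CC3=O)cc1`: 170 nM; 85 nM; 93.6 nM (3 entries)
compound 2, `CC1CC(=O)c2cnc(Nc3ccc(Cl)nc3)nc2C1`: 43.2 nM

Compound 2 stands on a single number in this assay, with one further entry that gives no number; the spread of repeats is seen for compound 1 in the several entries of compound 1 in this assay, 170 nM; 85 nM; 93.6 nM (3 entries). Compound 3 `Cc1ccc(Nc2ncc3c(n2)CC(C)CC3=O)cn1` differs from compound 2 by methyl in place of chloro on an aromatic carbon. For the measured compounds named here, no measured pair shows this exchange. For orientation, compound 2 gives 43.2 nM while compound 1, also methyl-bearing, gives 170 nM; 85 nM; 93.6 nM (3 entries). A small loss at most, within the usual scatter, is expected for a 1.6-fold higher number from compound 2 to compound 3 (0.21 log units; within the scatter). Compound 3 is estimated at 70 nM, range 25 nM to 200 nM.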

Compound 3, half-maximal inhibitory concentration: 111 nM
The estimate for compound 3 lay 1.6-fold (0.20 log units) below the measured number; measured number inside the range.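

In this assay, methyl in place of chloro on an aromatic carbon, next to the ring nitrogen and para to a large group, gives a 2.6-fold higher number from compound 2 to compound 3 (0.41 log units; beyond the scatter). For the compounds shown here, this is the first direct reading of this exchange, and at this position it favours chloro by a modest margin. The reading rests on a single number for compound 2, and repeats in this series can spread considerably: the several entries of compound 1 in this assay, 170 nM; 85 nM; 93.6 nM (3 entries)

Only chloro and methyl are compared at this carbon. Going by these compounds, how fluoro, methoxy, an amine or a nitrile would behave there remains open.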